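Replacing the phenoxy group of the core with chloro

The source may hold more compounds than are shown below. What is called first, only, known or untested is meant among the compounds shown, and "the series" means these compounds.

Compound 1 `Cc1nnsc1CO/N=C/c1c(C)nn(C)c1Oc1ccccc1Cl`, compound 2 `Cc1nnsc1CO/N=C/c1c(C)nn(C)c1Oc1ccc(Br)cc1` and compound 3 `Cc1ccc(Oc2c(/C=N/OCc3snnc3C)c(C)nn2C)cc1` share one core and differ only in the phenyl group on an oxygen on an aromatic ring. In a functional assay on SGC-7901 cells (Homo sapiens) for inhibition, read by MTT assay, with a stated time of 48 h (on this read-out lower numbers stand for stronger inhibition and higher numbers for weaker inhibition), compound 1 gives only a limit, > 50000 nM. In this assay compound 2 gives 15200 nM, and compound 3 gives 12800 nM. Exchange of the phenyl group brings an at least 3.2-fold lower number from compound 1 to compound 2 (0.51 log units; beyond the scatter) and an at least 3.9-fold lower number from compound 1 to compound 3 (0.59 log units; beyond the scatter), whereas a 1.2-fold lower number from compound 2 to compound 3 (0.07 log units; within the scatter). Compound 3 therefore holds the lowest of the two numbers, compound 2 sits within the scatter of it, and the remaining value is a limit.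

Compound 4 `Cc1nnsc1CO/N=C/c1c(C)nn(C)c1Cl` differs from compound 3 by chloro in place of 4-methylphenoxy on an aromatic carbon. Among the compounds with values here, no measured step removes the phenoxy group altogether: the steps from compound 1 to compound 2 and from compound 1 to compound 3 change the phenyl group, and the step from compound 2 to compound 3 swaps one substituent on it. Two of those three steps lie beyond the scatter, so losing the whole group is expected to give a larger step, most likely toward a higher number in this assay, with a fair chance of only a limit. Compound 4 is expected to show a 3.1-fold higher number from compound 3 to compound 4 (0.49 log units; beyond the scatter). Compound 4 is estimated at 40000 nM, within a range from 12000 nM to 150000 nM.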

Compound 4, half-maximal inhibitory concentration: > 50000 nM
Compound 4 gave a limit, no number; the forecaster's own chance of this, stated with the estimate: 45%; middle value at least 1.2-fold (0.09 log units) from the limit.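

Exchanging the whole group for chloro on this aromatic carbon gives an at least 3.9-fold higher number from compound 3 to compound 4 (0.59 log units; beyond the scatter) and an at least 3.2-fold higher number from compound 2 to compound 4 (0.51 log units; beyond the scatter), so in this assay this position is sensitive to losing the group as well as to changes on the phenyl ring. Compound 4, which has no six-membered aromatic ring at this place, gives only a limit, and so does compound 1, which keeps a phenyl group on the oxygen; among the compounds shown, a phenoxy group is therefore not sufficient for a measured number, and such numbers appear only with 4-bromophenoxy in compound 2 and 4-methylphenoxy in compound 3. The step from compound 1 to compound 4 cannot be read, because each of the two is a limit: the limit of > 50000 nM in this assay, at which 2 of the 4 values shown sit.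

The compounds shown leave open whether the oxygen link or the phenyl ring matters more at this place, which a phenylamino group or a methoxy group in the same place would help to separate. On these data alone, it is also open how an amine or a carboxylic acid on the phenyl group would compare with the methyl of compound 3 and the bromo of compound 2.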